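Adding trifluoromethyl to compound 1

A few compounds are considered here, and "the series" means these few. Any claim that something is new, unique, unknown or untested is made for them only; others in the source may bear on it.

Compound 1 (`c1ccc(COc2ccccc2Nc2ncnc3cc4c(cc23)OCCOCCO4)cc1`) was tested in a functional assay on MCF7 cells (Homo sapiens) for antiproliferative activity, read by MTT assay, with a stated time of 72 h (a higher number here means a weaker inhibitor, a lower number a stronger inhibitor), and compound 1 returned > 100000 nM (a limit of the assay, not a number). The starting point for this step is therefore a limit only. Going by the values given here, compound 2 (`O=[N+]([O-])c1ccc(COc2ccc(Nc3ncnc4cc5c(cc34)OCCOCCO5)cc2)cc1`) does give a number in this assay, with compound 2 reading 39700 nM (the only true number so far).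

Compound 3 (`FC(F)(F)c1ccc(COc2ccccc2Nc2ncnc3cc4c(cc23)OCCOCCO4)cc1`) keeps the core of compound 1 and carries trifluoromethyl in place of hydrogen on an aromatic carbon, para to a large group, so that benzyl becomes 4-(trifluoromethyl)benzyl (trifluoromethyl in place of hydrogen on an aromatic carbon). Among the compounds with values here, no measured pair isolates this change, so the expectation rests on very little. A small step towards stronger inhibition in this assay is expected at best, perhaps none beyond the scatter, and a second limit reading is quite possible. The estimated step is an at least 1.2-fold lower number from compound 1 to compound 3 (0.09 log units; that floor lies within the scatter) (an expectation set against a limit). For compound 3 the expected value is 80000 nM (estimated range 25000 nM to 200000 nM).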

Compound 3, half-maximal inhibitory concentration: > 100000 nM
Compound 3: no number, only a limit (the forecaster's own chance of this, stated with the estimate: 55%); at least 1.2-fold (0.09 log units) between middle value and limit.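

In this assay compound 3 reads > 100000 nM, a limit of the assay and not a number. Compound 1 also stands at a limit, so no step between compound 1 and compound 3 can be read: the limit of > 100000 nM in this assay, at which 2 of the 3 values shown sit.

The compounds shown leave open whether 4-(trifluoromethyl)benzyl in place of benzyl changes the reading in this assay at all.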